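A few compounds are considered here, and "the series" means these few. Any claim that something is new, unique, unknown or untested is made for them only; others in the source may bear on it.

Working notes on the series. Among the compounds with values here, compound 1 `O=c1cc(-c2ccccc2)oc2cc(N3COc4c(Br)cccc4C3)ccc12` is the weakest of the three measured members: in a functional assay on MCF7 cells (Homo sapiens) for inhibition, read by MTT assay, with a stated time of 48 h, tested at 60 ug/mL (on this read-out higher numbers stand for more inhibition of growth at the one concentration tested and lower numbers for less inhibition of growth), compound 1 gives 19.5%, the lowest of the three numbers in hand. Compound 2 `O=c1cc(-c2ccccc2)oc2cc(N3COc4c(Br)cc(Br)cc4C3)ccc12` gives 26.5% in this assay; the step of a number 7 percentage points higher from compound 1 to compound 2 (within the scatter) is bromo in place of hydrogen on an aromatic carbon and does not reach beyond the scatter. Within the data shown here, compound 3 `COc1cccc2c1OCN(c1ccc3oc(-c4ccccc4)cc(=O)c3c1)C2` gives 91.9% in this assay; it carries a methoxy group where compound 1 carries bromo, and the two values lie far apart, but no step between them has been worked out, so the two numbers are simply noted side by side.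

Compound 4 `Cc1cccc2c1OCN(c1ccc3c(=O)cc(-c4ccccc4)oc3c1)C2` is the unmeasured member. Its change from compound 1 is methyl in place of bromo on an aromatic carbon. Among the measured compounds shown here, no measured step exchanges bromo for methyl. For the measured compounds named here, the only measured step that alters a substituent on the shared core, a number 7 percentage points higher from compound 1 to compound 2 (within the scatter), stays within the scatter, so it gives no ground to expect a large shift. The high value of compound 3 shows that this part of the core can carry a substituent with a very different result, which widens the uncertainty without fixing a direction.

Compound 4 is therefore expected to give about 40% in this assay, with a range of 12% to 75%. This estimate means a step of a number 20.5 percentage points higher from compound 1 to compound 4 (beyond the scatter), expected to be modest and upward, with the range open to a much larger gain.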

Compound 4, percent growth inhibition at one concentration: 66.6%
For compound 4 the middle estimate is 26.6 percentage points below the measured one; measured number inside the range.
By their numbers in this assay, from the lowest: compounds 1 and 2 (each within the scatter of the next); then compound 4; then compound 3.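

In this assay, within the data shown here, methyl in place of bromo on this aromatic carbon gives a number 47.1 percentage points higher from compound 1 to compound 4 (beyond the scatter) and is the first step to lie beyond the scatter, whereas a number 7 percentage points higher from compound 1 to compound 2 (within the scatter) stays within it; a change of one heavy atom at this position can therefore move the read-out strongly, even though neither group counts as a hydrogen-bond donor or acceptor or carries a net charge. Compound 3, with methoxy on the same carbon, gives 91.9% and compound 4 gives 66.6%, so both compounds that lack bromo here stand well above compound 1 in the printed values. Nothing available bears on the reason for the effect of this change.

The compounds shown leave open whether an unsubstituted hydrogen, chloro, an amine, a carboxylic acid or a longer chain such as propyl on this carbon would follow methyl and methoxy or stay with bromo. They also leave open whether methyl here would keep its gain in the presence of the second bromo of compound 2.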